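A few compounds are considered here, and "the series" means these few. Any claim that something is new, unique, unknown or untested is made for them only; others in the source may bear on it.

In a functional assay on Jurkat cells (Homo sapiens) for inhibition (on this read-out lower numbers stand for stronger inhibition and higher numbers for weaker inhibition), three compounds have been measured. Compound 1 `CCOC(=O)c1cnc(NN2C(=O)C=C(c3ccccc3)C2=O)nc1C(F)(F)F` gives 3700 nM, compound 2 `CCOC(=O)c1cnc(NN2C(=O)C(C)=C(C)C2=O)nc1C(F)(F)F` gives 3900 nM, and compound 3 `CCOC(=O)c1cnc(N(C(C)=O)N2C(=O)C=C(C)C2=O)nc1C(F)(F)F` gives 410 nM. Compound 3 therefore stands lowest of the three, and its gaps to compound 1 and to compound 2 both lie beyond the usual scatter, so it is the strongest inhibitor so far. Compound 4 `CCOC(=O)c1cnc(N(C(=O)OCC)N2C(=O)C=C(C)C2=O)nc1C(F)(F)F` differs from compound 3 by one change: ethoxy in place of methyl on a carbonyl carbon. Within the data shown here, no pair of measured compounds shows this change, so nothing known here sets its size. The step is expected to be a 1.2-fold higher number from compound 3 to compound 4 (0.09 log units; within the scatter), small and possibly within the scatter in either direction. Compound 4 is therefore estimated at 500 nM, within a range from 150 nM to 1600 nM.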

Compound 4, half-maximal inhibitory concentration: 380 nM
Estimate against measurement, compound 4: 1.3-fold (0.12 log units) above, and the stated range covers the measured number.
By their numbers in this assay, from the lowest: compounds 4 and 3 (each within the scatter of the next); then compounds 1 and 2 (each within the scatter of the next).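

In this assay, ethoxy in place of methyl on a carbonyl carbon gives a 1.1-fold lower number from compound 3 to compound 4 (0.03 log units; within the scatter) and so leaves the read-out unchanged within the scatter. Among these compounds, the earlier compounds held no pair differing in one place, so this is the only single change whose size can be read, and it shows that this carbonyl carbon accepts the larger ethoxy group. No measurement here gives a reason for this result.

Going by these compounds, whether an amine or a longer chain such as butoxy would fit equally well on this carbonyl carbon stays open. Also open, on these data alone, is what acetyl or ethoxycarbonyl adds compared with the amide hydrogen, since compounds 1 and 2 also differ elsewhere.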